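A few compounds are considered here, and "the series" means these few. Any claim that something is new, unique, unknown or untested is made for them only; others in the source may bear on it.

Among the measured compounds shown here, compound 1 `O=C1O[C@@H](CO)CN1c1ccc(-n2cc(-c3ccccn3)cn2)c(F)c1` is the only member of this set to return a number in an ADME assay on L02 cells (Homo sapiens) for cytotoxicity, read by MTT assay, with a stated time of 48 h (on this read-out higher numbers stand for weaker inhibition and lower numbers for stronger inhibition), where compound 1 gives 59 ug/mL. Compound 2 `CN(CCC#N)C[C@H]1CN(c2ccc(-n3cc(-c4ccccn4)cn3)c(F)c2)C(=O)O1` reaches a limit of the assay: in this assay compound 2 gives > 400 ug/mL. Compound 3 `COC[C@H]1CN(c2ccc(-n3cc(-c4ccccn4)cn3)c(F)c2)C(=O)O1` likewise sits at a limit, and in this assay compound 3 gives > 400 ug/mL. Both changes at that place move the same way, an at least 6.7-fold higher number from compound 1 to compound 2 (0.83 log units; beyond the scatter) and an at least 6.7-fold higher number from compound 1 to compound 3 (0.83 log units; beyond the scatter), each ending at the limit of > 400 ug/mL in this assay, at which 2 of the 3 values shown sit. Compound 4 `O=C(NC[C@H]1CN(c2ccc(-n3cc(-c4ccccn4)cn3)c(F)c2)C(=O)O1)C(F)F` alters the same position, (((difluoromethyl)carbonyl)amino in place of hydroxy on a saturated chain carbon bound to a saturated ring carbon). Since two earlier changes at that place both carried the number to the limit, a higher number for compound 4 is expected in this assay, a 7.6-fold higher number from compound 1 to compound 4 (0.88 log units; beyond the scatter). Compound 4 is therefore estimated at 450 ug/mL, between 150 ug/mL and 1200 ug/mL.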

Compound 4, half-maximal inhibitory concentration: > 400 ug/mL
Compound 4 gave a limit, no number; the forecaster's own chance of this, stated with the estimate: 60%; the middle value does not contradict the limit.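

In this assay, the replacement of hydroxy by ((difluoromethyl)carbonyl)amino gives an at least 6.7-fold higher number from compound 1 to compound 4 (0.83 log units; beyond the scatter). Unlike the methoxy of compound 3, this entering group has the same hydrogen-bond donor and acceptor counts as hydroxy, yet the number still reaches a limit, and the steps among compounds 2, 3 and 4 cannot be read. All three replacements end at the same point: the limit of > 400 ug/mL in this assay, at which 3 of the 4 values shown sit.

As far as these compounds go, how far the true values of compounds 2, 3 and 4 differ remains open. So does whether a primary amine or a carboxylic acid at this place would also reach the limit.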